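The source may report more compounds than this note shows. Statements on the series, on what has been measured and on what is new or still open speak of the compounds shown alone.

In an assay on isolated protein for inhibition of thyroid hormone receptor alpha (Homo sapiens), read by fluorescence polarization (a lower number here means a stronger inhibitor, a higher number a weaker inhibitor), compound 2, `CC(C)N(C(=O)C1CCN(C(=O)c2ccc(S(C)(=O)=O)c([N+](=O)[O-])c2)CC1)C(C)C`, reaches only the limit of the assay, > 60000 nM. Compound 1, `CS(=O)(=O)c1ccc(C(=O)NCCCC(=O)N2Cc3ccccc3C2)cc1[N+](=O)[O-]`, likewise gives only a limit, > 60000 nM. Compound 3, `CN(Cc1ccccc1F)C(=O)CNC(=O)c1ccc(S(C)(=O)=O)c([N+](=O)[O-])c1`, also stops at a limit, > 60000 nM. Among the measured compounds shown here, all three values shown thus sit at the limit of > 60000 nM in this assay, at which 3 of the 3 values shown sit, so no measured step between compounds can be drawn. Compound 4, `CN(Cc1ccccc1F)C(=O)C1CCN(C(=O)c2ccc(S(C)(=O)=O)c([N+](=O)[O-])c2)CC1`, differs from compound 2 by (2-fluorobenzyl)(methyl)amino in place of diisopropylamino on a carbonyl carbon. Compound 3 carries the same (2-fluorobenzyl)(methyl)amino group. For the measured compounds named here, with every value so far at the limit, the step from compound 2 to compound 4 is expected to be none beyond the scatter, a number no higher from compound 2 to compound 4 (the limit leaves the size open). Compound 4 is therefore estimated in this assay at 60000 nM, between 25000 nM and 150000 nM, and most likely again only a limit.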

Compound 4, half-maximal inhibitory concentration: > 60000 nM
Compound 4 gave a limit, no number; the forecaster's own chance of this, stated with the estimate: 85%; the middle value lies on the limit itself.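

Compound 4, like compound 2, gives only a limit, so no step can be read between them: the limit of > 60000 nM in this assay, at which 4 of the 4 values shown sit. The compounds shown leave open how (2-fluorobenzyl)(methyl)amino compares with diisopropylamino on a carbonyl carbon, and whether any of the four has a measurable strength in this assay.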